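Working notes: compound 4 after compound 3 in cytotoxicity

This account rests on a few compounds, and the source may have more. Where it says the series, first, only, none or still open, it means among the compounds named here.

Measured so far:
Compound 1, `O=C(/C=C/c1ccc2c(c1)B(O)OC2)c1cccs1`, gives 14200 nM in a functional assay on HCT-116 cells (Homo sapiens) for cytotoxicity, read by MTT assay, with a stated time of 48 h; a lower number here means a stronger inhibitor, a higher number a weaker inhibitor.
Compound 2, `O=C(/C=C/c1ccc2c(c1)B(O)OC2)c1ccc(I)cc1`, gives 11600 nM in this assay.
Compound 3, `O=C(/C=C/c1ccc2c(c1)B(O)OC2)c1cccc(F)c1`, gives 6700 nM in this assay.

Compound 3 holds the lowest of the three numbers. Its nearest neighbour is compound 2, with a gap that stays within the scatter (a 1.7-fold lower number from compound 2 to compound 3 (0.24 log units; within the scatter)); the widest gap is a modest step that just clears the scatter (a 2.1-fold lower number from compound 1 to compound 3 (0.33 log units; beyond the scatter)). Compound 3 is therefore not to be called the most potent of the set, since compound 2 sits within the scatter of it.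

Compound 4, `Cc1cccc(C(=O)/C=C/c2ccc3c(c2)B(O)OC3)c1`, differs from compound 3 in one place: methyl in place of fluoro on an aromatic carbon, a change on a six-membered aromatic ring of carbon only, meta to a large group. Among the measured compounds shown here, no measured step exchanges one group for another on that ring at that place; every measured step replaces the whole group on the carbonyl carbon, and all of them were small (a 1.2-fold lower number from compound 1 to compound 2 (0.09 log units; within the scatter), a 1.7-fold lower number from compound 2 to compound 3 (0.24 log units; within the scatter), a 2.1-fold lower number from compound 1 to compound 3 (0.33 log units; beyond the scatter)). For the measured compounds named here, the series so far shows small movements only, so nothing supports a large step here in either direction.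

Compound 4 is expected to give about 7500 nM, with a range from 3000 nM to 18000 nM. The expected step is a 1.1-fold higher number from compound 3 to compound 4 (0.05 log units; within the scatter), which is to say no move beyond the scatter.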

Compound 4, half-maximal inhibitory concentration: 6700 nM
Beside the measured number, compound 4's estimate is 1.1-fold (0.05 log units) above it, within the range that was stated.
By their numbers in this assay, from the lowest: compounds 3, 4, 2 and 1 (each within the scatter of the next, the first and the last beyond it).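

In this assay, among the compounds shown here, the exchange of methyl for fluoro on an aromatic carbon meta to a large group is the first step that alters one group on the ring rather than replacing the whole group on the carbonyl carbon, and it gives no readable change (no change at the digits printed from compound 3 to compound 4 (within the scatter)). The 3-methylphenyl compound also stands where the 3-fluorophenyl compound stood relative to the other two compounds, with one gap within the scatter (a 1.7-fold lower number from compound 2 to compound 4 (0.24 log units; within the scatter)) and one modest gap just beyond it (a 2.1-fold lower number from compound 1 to compound 4 (0.33 log units; beyond the scatter)), so at this place the two groups cannot be told apart in this cell read-out. No measurement on hand bears on why the number stays put.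

On these data alone, it remains open whether this insensitivity extends to groups unlike these two, such as an amine, a carboxylic acid or a longer chain at the same place. As far as these compounds go, it also remains open whether methyl or fluoro at another carbon of this ring would leave the number equally unmoved.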